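The compounds below may be only part of what the source reports. "The series", "measured", "known", "first", "only" and "open" are said of these compounds alone.

Measured compounds:
- compound 1 `C/C(=C\c1cc(-c2ccccc2)cs1)C(N)=O` — in a functional assay on HO8910 cells (Homo sapiens) for cytotoxicity, read by CCK-8 assay, with a stated time of 24 h (on this read-out higher numbers stand for weaker inhibition and lower numbers for stronger inhibition), compound 1 gives > 50000 nM, which is a limit of the assay and not a number.
- compound 2 `C/C(=C\c1cc(-c2ccccc2C)cs1)C(N)=O` — in this assay compound 2 gives 15200 nM.

From the compounds shown here alone, compound 1 therefore stands only at the limit of > 50000 nM in this assay, at which 1 of the 2 values shown sits; where it actually lies below that is unknown. Within the data shown here, the one measured step from it is methyl in place of hydrogen on an aromatic carbon, which gives an at least 3.2-fold lower number from compound 1 to compound 2 (0.51 log units; beyond the scatter), a step that can only be stated as a lower bound since compound 1 is at the limit.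

Compound 3 `C/C(=C\c1cc(-c2ccc(Cl)cc2)cs1)C(N)=O` differs from compound 1 by chloro in place of hydrogen on an aromatic carbon. This is a different substituent at a different place on the same phenyl ring, so the step to compound 2 bears on it only as a sign that a single small substituent on that ring can bring the value off the limit. Expected is a step of comparable size, an at least 2.5-fold lower number from compound 1 to compound 3 (0.39 log units; beyond the scatter), toward stronger inhibition, with a real chance that the value again comes back only as a limit. The estimate for compound 3 in this assay is 20000 nM, expected to fall between 6000 nM and 60000 nM.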

Compound 3, half-maximal inhibitory concentration: > 50000 nM
Compound 3 was reported as a limit (the forecaster's own chance of this, stated with the estimate: 35%); middle value at least 2.5-fold (0.39 log units) from the limit.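

In this assay compound 3 gives > 50000 nM, which is a limit and not a number, and compound 1 stands at the same limit, so no step between compound 1 and compound 3 can be read: the limit of > 50000 nM in this assay, at which 2 of the 3 values shown sit.

The compounds shown leave open where compound 1 and compound 3 actually lie, and therefore whether chloro in place of hydrogen changes the value at all.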